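Adding an Amino Group to a Pyrazoline Hydroxyphenyl Series

This account rests on a few compounds, and the source may have more. Where it says the series, first, only, none or still open, it means among the compounds named here.

Compound 2 `Oc1ccc(C2CC(c3ccccc3)=NN2c2ccc(Cl)cc2)cc1` is the starting point of this comparison. In an assay on isolated protein for inhibition of protein kinase C iota type (Homo sapiens), tested at 20 uM (a higher number here means more inhibition at the concentration tested (going by the name of the read-out), a lower number less inhibition), compound 2 gives 31.6%. Compound 1 `CC(C)(C)C1=NN(c2ccc(F)c(Cl)c2)C(c2ccc(O)cc2)C1` gives 31.6%, which sits level with compound 2 at the digits printed; together the two share the lowest number among the three measured compounds. Going by the values given here, compound 3 `Oc1ccc(C2CC(c3ccccc3)=NN2c2cccc(Cl)c2)cc1` gives 45.5%, and the step of a number 13.9 percentage points higher from compound 2 to compound 3 (beyond the scatter) is the only change in the set that lies beyond the usual scatter.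

Compound 4 `Nc1ccc(C2=NN(c3ccc(Cl)cc3)C(c3ccc(O)cc3)C2)cc1` has not yet been measured. It differs from compound 2 in one spot: amino in place of hydrogen on an aromatic carbon. Among the compounds with values here, the difference sits on the phenyl attached to the carbon of the shared core, not on the ring carried by the ring nitrogen, so the one measured step, which moves a chlorine between positions on that nitrogen-borne ring, does not speak to it directly. Within the data shown here, no measured pair shows what an amino group does here. With nothing to point either way, the expectation for compound 4 is a number close to that of compound 2, a step of a number 3.4 percentage points higher from compound 2 to compound 4 (within the scatter) that stays within the scatter. Compound 4 is therefore estimated at 35%, within a range from 15% to 55%.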

Compound 4, a percentage reported as inhibition, at one concentration (the size of the read-out at that concentration, not a potency): 38.7%
Compound 4: middle estimate off by 3.7 percentage points, on the low side; the measured number falls inside the stated range.
By their numbers in this assay, from the lowest: compounds 1, 2, 4 and 3 (each within the scatter of the next, the first and the last beyond it).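

Going by these compounds alone, this is the first measured change on the phenyl attached to the carbon of the shared core, and it gives a number 7.1 percentage points higher from compound 2 to compound 4 (within the scatter), so placing an amino group para to a large group on that ring leaves the reading in this assay indistinguishable from that of the unsubstituted phenyl. The contrast lies with the other aryl ring: moving the chlorine there gives a number 13.9 percentage points higher from compound 2 to compound 3 (beyond the scatter), so among the single changes shown, only the one on the nitrogen-borne ring stands clear of the usual variation between repeats, although a single amino group cannot show how other groups on the carbon-borne phenyl would behave. No measurement here explains either result.

Going by these compounds, it remains open whether a larger or differently charged group at the same place, such as a carboxylic acid, an aminomethyl group or a longer chain ending in an amine, would move the number beyond the scatter. Also open, on these data alone, is how the 4-aminophenyl group would read when paired with the 3-chlorophenyl group of compound 3, since the two changes appear here only separately.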